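Lengthening the ester chain on compound 2

The compounds below may be only part of what the source reports. "The series", "measured", "known", "first", "only" and "open" are said of these compounds alone.

Measured so far in a functional assay on HeLa S3 cells (Homo sapiens) for cytotoxicity; a lower number here means a stronger inhibitor, a higher number a weaker inhibitor:
compound 1 `OC1C=C[C@]2(O)CCO[C@@H]2C1`: > 100 ug/mL, a limit of this assay
compound 2 `CC(=O)O[C@]12C=CC(O)C[C@H]1OCC2`: > 100 ug/mL, a limit of this assay

Both values are limits rather than numbers. Compound 1 reaches only the limit of this assay. Compound 2 reaches the same limit in this assay. Among the compounds with values here, the one measured step, a step that the two limits leave unreadable from compound 1 to compound 2, cannot be given a size, because the limit of > 100 ug/mL in this assay, at which 2 of the 2 values shown sit, places both compounds at the same limit.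

Compound 3 `CCCC(=O)O[C@]12C=CC(O)C[C@H]1OCC2` differs from compound 2 by ethyl in place of hydrogen on a saturated chain carbon bound to a carbonyl carbon. Within the data shown here, no measured step bears on this change, and the only step in hand, acetyl in place of hydrogen, has no readable size. Nothing in the data suggests compound 3 will leave the range where compounds 1 and 2 sit, so the expected step that the limit leaves unreadable from compound 2 to compound 3 is none beyond the scatter, with a high chance that again only a limit is reported. Compound 3 is estimated at 150 ug/mL, between 60 ug/mL and 400 ug/mL.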

Compound 3, half-maximal inhibitory concentration: 8.8 ug/mL
Compound 3: middle estimate off by 17-fold (1.23 log units), on the high side, and the stated range ends above it.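

In this assay, within the data shown here, the ester chain is the first place in this set where a change has a readable effect: ethyl in place of hydrogen on a saturated chain carbon bound to a carbonyl carbon gives an at least 11-fold lower number from compound 2 to compound 3 (1.05 log units; beyond the scatter). The longer ester also gives an at least 11-fold lower number from compound 1 to compound 3 (1.05 log units; beyond the scatter), so in this set the longer ester, and not the acetyl ester of compound 2, is what brings a measurable value. Both steps are minimum sizes, and the step from compound 1 to compound 2 cannot be read, because compound 1 and compound 2 each sit at a limit: the limit of > 100 ug/mL in this assay, at which 2 of the 3 values shown sit.

On these data alone, with only one chain beyond acetyl, whether a longer chain lowers the number further remains open. So does whether a benzoyl ester or an amide in the same place would match compound 3.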